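The source may hold more compounds than are shown below. What is called first, only, known or untested is meant among the compounds shown, and "the series" means these compounds.

Measured compounds in an in vitro assay on BTI-TN-5B1-4 cells for inhibition of Amine oxidase [flavin-containing] B (Homo sapiens); a higher number here means a weaker inhibitor, a lower number a stronger inhibitor:
compound 1 `Cc1ccc(C2CC(=O)c3ccc(C)cc3O2)cc1`: 500 nM
compound 2 `Fc1ccc(-c2cc(=S)c3ccc(F)cc3o2)cc1`: 6890 nM
compound 3 `COc1ccc2c(c1)OC(c1ccc(C)cc1)CC2=O`: 550 nM

Compound 2 stands at the highest number of the three in this assay; compound 3 with 550 nM and compound 1 with 500 nM both sit well below it, each gap beyond the scatter. For the measured compounds named here, compound 2 is also the only member built on its core; compound 1 and compound 3 share a different core.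

Compound 4 `Cc1ccc(-c2cc(=S)c3ccc(F)cc3o2)cc1` keeps the core of compound 2 and differs from it in one place: methyl in place of fluoro on an aromatic carbon. Going by the values given here, the only measured step in the set, a 1.1-fold higher number from compound 1 to compound 3 (0.04 log units; within the scatter), exchanges methoxy for methyl on the other core and lies within the scatter; it does not test a fluoro-to-methyl exchange, and no measured pair does. Compounds 1 and 3 carry the methyl-bearing aryl of compound 4, but on their own core, so their numbers give no direct guide here. With nothing in the data pointing either way, the expected step from compound 2 is small, a 1.5-fold lower number from compound 2 to compound 4 (0.19 log units; within the scatter), and not clearly beyond the scatter. For compound 4 the estimate is 4500 nM, with a range from 1500 nM to 13000 nM.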

Compound 4, half-maximal inhibitory concentration: 1610 nM
Estimate against measurement, compound 4: 2.8-fold (0.45 log units) above, within the range that was stated.
By their numbers in this assay, from the lowest: compounds 1 and 3 (each within the scatter of the next); then compound 4; then compound 2.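

In this assay the aromatic carbon para to a large group on the core of compound 2 proves sensitive to a one-atom exchange: methyl in place of fluoro gives a 4.3-fold lower number from compound 2 to compound 4 (0.63 log units; beyond the scatter), although the count of heavy atoms, hydrogen-bond donors and acceptors and the net charge stay the same. For the compounds shown here, the only earlier step, a 1.1-fold higher number from compound 1 to compound 3 (0.04 log units; within the scatter), belongs to the other core and a different exchange, so it gave no sign of this sensitivity. Nothing available explains the size or direction of the new step.

As far as these compounds go, it remains open whether a longer chain such as propyl, a chloro group or an amine at this position would extend the step or reverse it. From the compounds shown here alone, the same fluoro-to-methyl exchange on the core of compound 1 also remains open, so the step cannot yet be said to hold beyond this core.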